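Solubility Limits and a Dimethylamino Swap on a Shared Core

The source may report more compounds than this note shows. Statements on the series, on what has been measured and on what is new or still open speak of the compounds shown alone.

Compound 1 `Cc1noc(-c2nc(C)c3c(c2N)C(=O)N(Cc2ccc(Cl)cc2)C3=O)n1` and compound 2 `COc1cccc(CN2C(=O)c3c(C)nc(-c4nc(C)no4)c(N)c3C2=O)c1` share one core and differ only in the aryl group on the benzyl-type carbon. In a physicochemical assay for solubility, using the shake flask method, in simulated intestinal fluid, measured as kinetic solubility, with a stated time of 2 h, at 25 degrees C, at pH 6.5 (on this read-out lower numbers stand for lower solubility and higher numbers for higher solubility), compound 1 gives < 5000 nM, which is a limit of the assay rather than a number. In this assay compound 2 likewise gives < 5000 nM, again a limit and not a measured value. The step that the two limits leave unreadable from compound 1 to compound 2 therefore cannot be read, and the only firm point of reference is the limit of < 5000 nM in this assay, at which 2 of the 2 values shown sit, the floor at which both values sit. Within the data shown here, compound 2 thus stands at the lower boundary of what this assay resolves, with no measured step to anchor it.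

Compound 3 `Cc1noc(-c2nc(C)c3c(c2N)C(=O)N(Cc2ccc(N(C)C)cc2)C3=O)n1` differs from compound 2 by the change (4-(dimethylamino)phenyl in place of 3-methoxyphenyl on a saturated chain carbon bound to an amide-type nitrogen in a ring). Among the measured compounds shown here, no measured step bears on this change, since the one step available is unreadable. The expected step that the limit leaves unreadable from compound 2 to compound 3 is therefore an estimate made without a measured precedent. Compound 3 is expected to give about 4000 nM, in the range 1000 nM to 15000 nM, with a sizeable chance that this assay again returns only a limit.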

Compound 3, solubility: 7400 nM
Compound 3: the middle estimate sits 1.9-fold (0.27 log units) below what was measured, and the stated range covers the measured number.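

Of the three compounds, only compound 3 gives a number rather than a limit in this assay, so this position, on a saturated chain carbon bound to an amide-type nitrogen in a ring, can hold an aryl group with which the read-out is a number on this core. Putting 4-(dimethylamino)phenyl in place of 3-methoxyphenyl gives an at least 1.4-fold higher number from compound 2 to compound 3 (0.17 log units; that floor lies within the scatter), and dimethylamino in place of chloro on an aromatic carbon gives an at least 1.4-fold higher number from compound 1 to compound 3 (0.17 log units; that floor lies within the scatter). Each step is only a floor, and the reference point for both remains a limit: the limit of < 5000 nM in this assay, at which 2 of the 3 values shown sit.

The compounds shown leave open whether another amine on the same aromatic carbon, such as a pyrrolidine or a morpholine, or a carboxylic acid there, would also give a number in this assay, and how large the true steps to compound 3 are. The step between the two compounds that stand only as limits still cannot be read.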